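A few compounds are considered here, and "the series" means these few. Any claim that something is new, unique, unknown or untested is made for them only; others in the source may bear on it.

Series notes. Compound 1 `CCOC(=O)c1c(-c2cccc(OC)c2)[nH]c2cc(Cl)c(OC)cc2c1=O` carries a methoxy on the pendant aryl ring; compound 2 `CCOC(=O)c1c(-c2cccc(Oc3ccccc3)c2)[nH]c2cc(Cl)c(OC)cc2c1=O` carries a phenoxy in its place. In an ADME assay on Raji cells (Homo sapiens) for cytotoxicity, read by luminescence, with a stated time of 72 h (a higher number here means that more compound is needed for the effect, a lower number that less compound is needed), compound 1 gives only a limit of the assay, > 21500 nM. In this assay compound 2 likewise gives only a limit, > 21500 nM. The step that the two limits leave unreadable from compound 1 to compound 2 therefore cannot be read; the change is phenyl in place of methyl on an oxygen on an aromatic ring.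

Compound 3 `CCOC(=O)c1c(-c2cccc(OC)c2)[nH]c2cc(OC)c(F)cc2c1=O` keeps the methoxy on the pendant aryl ring but differs from compound 1 in the core; the difference between the two cores is not broken down here. In this assay compound 3 also gives only a limit, > 21500 nM. Within the data shown here, all three values so far sit at the limit of > 21500 nM in this assay, at which 3 of the 3 values shown sit.

Compound 4 `CCOC(=O)c1c(-c2cccc(Oc3ccccc3)c2)[nH]c2cc(OC)c(F)cc2c1=O` is not yet measured. Its change from compound 3 is phenyl in place of methyl on an oxygen on an aromatic ring, the same change as from compound 1 to compound 2, at the same place on the same kind of oxygen. Because compound 3 gives > 21500 nM and the matched pair gives a step that the two limits leave unreadable from compound 1 to compound 2, the step that the limit leaves unreadable from compound 3 to compound 4 is expected to be small and most likely unreadable. Compound 4 is estimated at 30000 nM, with another limit the likeliest outcome.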

Compound 4, half-maximal effective concentration: > 21500 nM
Compound 4: no number, only a limit; the forecaster's own chance of this, stated with the estimate: 85%; the middle value is on the limit's open side.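

In this assay compound 4 gives only a limit, > 21500 nM. The step from compound 3 to compound 4 cannot be read, as both values are limits.

The compounds shown leave open what concentration, if any, gives the half-maximal effect for these four structures, and how methoxy and phenoxy compare in this assay: the limit of > 21500 nM in this assay, at which 4 of the 4 values shown sit.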